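The source may report more compounds than this note shows. Statements on the series, on what has been measured and on what is new or still open speak of the compounds shown alone.

Compound 1 `COc1ccc(C(=O)O[C@H]2CC(C)=C[C@H](OC(C)=O)[C@@]3(C)[C@@H](OC(C)=O)C[C@@](O)(C(C)C)[C@H]23)cc1`: 23300 nM
Compound 2 `COc1ccc(C(=O)O[C@H]2CC(C)=CC[C@@]3(C)CC[C@@](O)(C(C)C)[C@H]23)cc1`: 31900 nM
Compound 3 `COc1ccc(C(=O)O[C@H]2CC(C)=C[C@H](O)[C@@]3(C)[C@@H](OC(C)=O)C[C@@](O)(C(C)C)[C@H]23)cc1`: 79600 nM

These three were measured in a functional assay on A549 cells (Homo sapiens) for cytotoxicity, read by MTT assay, with a stated time of 72 h; on this read-out lower numbers stand for stronger inhibition and higher numbers for weaker inhibition. Compound 1 gives the lowest of the three numbers; compound 2 lies within the scatter of it, while compound 3 sits clearly higher. Compound 4 `COc1ccc(C(=O)O[C@H]2CC(C)=C[C@H](OC(C)=O)[C@]3(C)[C@@H]2[C@](O)(C(C)C)C[C@@H]3O)cc1` has not yet been measured. It differs from compound 1 in one place: hydrogen in place of acetyl on an oxygen on a saturated carbon. Going by the values given here, the one step of this same kind already seen is a 3.4-fold higher number from compound 1 to compound 3 (0.53 log units; beyond the scatter), where the acetyl was removed from the other oxygen on a saturated carbon. On that basis the study expects the step to compound 4 to run the same way, a modest rise in the number, a 2.4-fold higher number from compound 1 to compound 4 (0.37 log units; beyond the scatter). Compound 4 is therefore estimated at 55000 nM, within 22000 nM to 130000 nM.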

Compound 4, half-maximal inhibitory concentration: > 100000 nM
Compound 4 was reported as a limit; the forecaster's own chance of this, stated with the estimate: 10%; at least 1.8-fold (0.25 log units) between middle value and limit.
By their numbers in this assay, from the lowest: compounds 1 and 2 (each within the scatter of the next); then compound 3. At a limit, above all of these: compound 4.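

In this assay, the change from acetoxy to hydroxy at this position gives an at least 4.2-fold higher number from compound 1 to compound 4 (0.63 log units; beyond the scatter). Together with a 3.4-fold higher number from compound 1 to compound 3 (0.53 log units; beyond the scatter), this shows that losing the acetyl raises the number beyond the scatter at both oxygens on saturated carbons, not at one alone. Compound 4 is known here only as a limit, so the full size of its step stays unknown: the limit of > 100000 nM in this assay, at which 1 of the 4 values shown sits.

As far as these compounds go, whether a methyl ether or a longer acyl chain such as butyryl on this oxygen would hold the number of compound 1 remains open. Also open, from the compounds shown here alone, is whether this position matters more than the other acetoxy position, since a limit cannot settle that.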